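Cyclopropyl to cyclobutyl on the amide carbonyl, second core

This account rests on a few compounds, and the source may have more. Where it says the series, first, only, none or still open, it means among the compounds named here.

Measured compounds:
- compound 1, `COc1ccc(N)c(C2=NN(C(=O)C3CC3)C(C)(C)S2)c1`: 90.1%
- compound 2, `COc1ccc(N)c(C2=NN(C(=O)C3CCC3)C(C)(C)S2)c1`: 57.8%
- compound 3, `CC1(C)SC(c2cc(Cl)ccc2N)=NN1C(=O)C1CC1`: 23.2%

All three were run in an assay on isolated protein for inhibition of Nitric oxide synthase, inducible (Homo sapiens), read by scintillation counting, with a stated time of 30 min, tested at 50 uM; a lower number here means less inhibition, a higher number more inhibition at the concentration tested (going by the name of the read-out). Compound 1 gives the highest number of the three, and its steps to compound 2 and to compound 3 are both beyond the scatter. Within the core of compound 1, the change cyclobutyl in place of cyclopropyl on a carbonyl carbon gives a number 32.3 percentage points lower from compound 1 to compound 2 (beyond the scatter). The two cores differ by chloro in place of methoxy on an aromatic carbon, and that change alone gives a number 66.9 percentage points lower from compound 1 to compound 3 (beyond the scatter), so compound 3 stands lowest of the three measured compounds, with every step to it beyond the scatter.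

Compound 4, `CC1(C)SC(c2cc(Cl)ccc2N)=NN1C(=O)C1CCC1`, has not yet been measured in this assay. It carries the change cyclobutyl in place of cyclopropyl on a carbonyl carbon on the core of compound 3. The place of this change reads the same as for the change from compound 1 to compound 2, so it is the same change, now made on the second core. Among the compounds with values here, only one instance of it has a measured outcome, so how far it carries over is open.

Within the data shown here, the expectation for compound 4 rests on two things: the starting number of compound 3, 23.2%, which leaves little room below it, and the single earlier step of a number 32.3 percentage points lower from compound 1 to compound 2 (beyond the scatter), which was downward and large. A step of a number 11.2 percentage points lower from compound 3 to compound 4 (beyond the scatter) is therefore expected from compound 3 to compound 4, smaller than the earlier one because compound 3 gives 23.2% and leaves little room below it. Compound 4 is estimated at 12% in this assay, between 0% and 30%.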

Compound 4, a percentage reported as inhibition, at one concentration (the size of the read-out at that concentration, not a potency): -4.65%
Compound 4: middle estimate off by 16.7 percentage points, on the high side; measured number below the stated range.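

In this assay, cyclobutyl in place of cyclopropyl on the carbonyl carbon gives a number 27.9 percentage points lower from compound 3 to compound 4 (beyond the scatter), so the change carries over from the core of compound 1 to the core of compound 3 with a similar size, even from the lower starting number: the same change on two cores in this assay, a number 32.3 percentage points lower (beyond the scatter) from compound 1 to compound 2 and a number 27.9 percentage points lower (beyond the scatter) from compound 3 to compound 4, 4.5 percentage points apart, within the scatter of two such steps. Chloro in place of methoxy on the aromatic carbon gives a number 62.5 percentage points lower from compound 2 to compound 4 (beyond the scatter), and it also carries over, here from the cyclopropyl amide to the cyclobutyl amide: the same change on two cores in this assay, a number 66.9 percentage points lower (beyond the scatter) from compound 1 to compound 3 and a number 62.5 percentage points lower (beyond the scatter) from compound 2 to compound 4, 4.5 percentage points apart, within the scatter of two such steps. Both comparisons come from the same four compounds, so they are one observation read in two directions; they show that the two changes act about independently in this set, but they give no rule for other cores, no potency, and no reason for either fall.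

The compounds shown leave open whether the fall continues with a larger ring such as cyclopentyl on the carbonyl, or how an open chain such as isopropyl compares with cyclopropyl there. They also leave open how other groups in place of methoxy, such as ethoxy, fluoro or methyl, would read on the cyclopropyl amide.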